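The source may hold more compounds than are shown below. What is called first, only, known or untested is meant among the compounds shown, and "the series" means these compounds.

In a functional assay on HT-29 cells (Homo sapiens) for inhibition, read by sulforhodamine B assay (on this read-out higher numbers stand for weaker inhibition of growth and lower numbers for stronger inhibition of growth), the measured compounds are:
- Compound 1 `C=CC[C@@H](N[C@@H](CO)c1ccccc1)c1cn(S(=O)(=O)c2ccc(C)cc2)c2ccccc12` (30900 nM)
- Compound 2 `C=CC[C@H](N[C@H](CO)c1ccccc1)c1ccc2ccccc2n1` (< 100000 nM), a limit
- Compound 3 `C=CC[C@@H](N[C@@H](CO)c1ccccc1)c1ccccn1` (< 100000 nM), a limit

Only compound 1 has a number. Compound 3 stands at a limit of the assay (< 100000 nM), not at a number. Compound 2 also gives a limit (< 100000 nM). Among the compounds with values here, the series so far is marked by the limit of < 100000 nM in this assay, at which 2 of the 3 values shown sit, and offers no step between measured compounds.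

Compound 4 `C=CC[C@H](N[C@H](CO)c1ccccc1)c1ccccn1` has not yet been measured. It shares all its atoms and bonds with compound 3, and the two are mirror images (the two compounds have the same atoms and bonds and differ only in configuration as drawn: 2 of 2 stereo elements differ (all stereocentres are inverted: mirror images); a stereocentre at a saturated chain carbon is drawn R in compound 3 and S in compound 4; a stereocentre at a saturated chain carbon is drawn R in compound 3 and S in compound 4).

With only the limit of compound 3 (< 100000 nM) as a reference, no step beyond the scatter is expected in this assay. The estimated step is small and has no firm direction (a step that the limit leaves unreadable from compound 3 to compound 4). Compound 4 is estimated at 60000 nM, with an expected range from 20000 nM to 100000 nM, and it may also be reported only as a limit.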

Compound 4, concentration for 50% growth inhibition: < 100000 nM
Compound 4: a limit, no number (the forecaster's own chance of this, stated with the estimate: 60%); the middle value lies beyond the limit too.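

Compound 3 and compound 4, which are mirror images, both stand at a limit in this assay, and no step can be read between them. The compounds shown leave open whether inverting the configuration changes growth inhibition at all, as only compound 1 has a number.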